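The source may hold more compounds than are shown below. What is called first, only, known or untested is meant among the compounds shown, and "the series" means these compounds.

The measured compounds:
Compound 1 `CN(C(=O)NC(=O)c1cccc(C(F)(F)F)c1)c1nc(C(F)(F)F)c(C(=O)N/N=C/c2cccc(C(F)(F)F)c2)s1`; in a functional assay on HeLa cells (Homo sapiens) for inhibition, read by MTT assay, with a stated time of 72 h (a lower number here means a stronger inhibitor, a higher number a weaker inhibitor), compound 1 gives 4.81 ug/mL.
Compound 2 `CN(C(=O)NC(=O)c1ccc([N+](=O)[O-])cc1)c1nc(C(F)(F)F)c(C(=O)N/N=C/c2cccc(C(F)(F)F)c2)s1`; in this assay compound 2 gives 4.12 ug/mL.
Compound 3 `CN(C(=O)NC(=O)c1cccc(C(F)(F)F)c1)c1nc(C(F)(F)F)c(C(=O)N/N=C/c2ccc(C(F)(F)F)cc2)s1`; in this assay compound 3 gives 7.35 ug/mL.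

Compound 1 stands second highest of the three numbers. Its nearest neighbour is compound 2, with a 1.2-fold lower number from compound 1 to compound 2 (0.07 log units; within the scatter), and its furthest is compound 3, with a 1.5-fold higher number from compound 1 to compound 3 (0.18 log units; within the scatter). Both steps lie within the scatter, so the three compounds cannot be put in any order on these numbers.

Compound 4 `CN(C(=O)NC(=O)c1cccc(C(F)(F)F)c1)c1nc(C(F)(F)F)c(C(=O)N/N=C/c2cc(C(F)(F)F)cc(C(F)(F)F)c2)s1` is not yet measured. It differs from compound 1 in one place: trifluoromethyl in place of hydrogen on an aromatic carbon. For the measured compounds named here, the ring that receives the new group is the same ring on which compound 3 differs from compound 1, so the one step that bears on the present change is a 1.5-fold higher number from compound 1 to compound 3 (0.18 log units; within the scatter), which stayed within the scatter. The other measured step, a 1.2-fold lower number from compound 1 to compound 2 (0.07 log units; within the scatter), concerns a different ring and was likewise within the scatter. Going by the values given here, nothing measured so far points to a step beyond the scatter in this assay, though a second trifluoromethyl on this ring is untested, and the range is kept wide. Compound 4 is therefore expected to give 5.5 ug/mL, between 2.5 ug/mL and 12 ug/mL, which means an expected 1.1-fold higher number from compound 1 to compound 4 (0.06 log units; within the scatter).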

Compound 4, half-maximal inhibitory concentration: 5.34 ug/mL
Compound 4: the middle estimate sits 1.0-fold (0.01 log units) above what was measured; measured number inside the range.
By their numbers in this assay, from the lowest: compounds 2, 1, 4 and 3 (each within the scatter of the next).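

In this assay, placing a trifluoromethyl on an aromatic carbon of the ring that already carries one, meta to that trifluoromethyl group, gives a 1.1-fold higher number from compound 1 to compound 4 (0.05 log units; within the scatter). Compound 3 had shown only that the single trifluoromethyl could sit elsewhere on this ring without a step beyond the scatter; compound 4 adds that the ring can also carry a second trifluoromethyl, with its 4 extra heavy atoms, and the step still stays within the scatter, so at this position in this assay the number does not respond measurably to the added group. Nothing measured here accounts for this result, and no explanation can be offered for it.

All the steps shown involve either a trifluoromethyl on this ring or a swap of the aromatic group on the carbonyl carbon, so it remains open whether any change at this position can take the number beyond the scatter. An amine or a carboxylic acid on the same aromatic carbon would test this with a group of a different kind from trifluoromethyl, and a longer chain there would test it with a larger one.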